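A few compounds are considered here, and "the series" means these few. Any claim that something is new, unique, unknown or untested is made for them only; others in the source may bear on it.

Compound 1 `ONc1ccc(CNc2cc(Br)cc3[nH]ncc23)cc1` and compound 2 `Oc1ccc(CNc2cc(Br)cc3[nH]ncc23)c(O)c1` share the same core and are both measured in an assay for inhibition of Tryptophan 2,3-dioxygenase (Homo sapiens), with a stated time of 1 h, tested at 10 uM; on this read-out lower numbers stand for less inhibition and higher numbers for more inhibition at the one concentration tested (going by the name of the read-out). Compound 1 gives 6% in this assay, a small degree of inhibition at the single concentration tested. Compound 2 is reported in this assay as "not active" (no number reported); no number stands behind this result, so compound 2 can only be placed among the compounds that show essentially no inhibition. The next compound, compound 3 `Cc1cc(O)ccc1CNc1cc(Br)cc2[nH]ncc12`, differs from compound 2 in one place: methyl in place of hydroxy on an aromatic carbon. Going by the values given here, no measured pair of compounds differing in one place is available here, so the size of this step in this assay can only be expected, not read off: a step of no size beyond the usual scatter seems most plausible, in either direction. Compound 3 is therefore expected to show 5%, within a range from 0% to 20%.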

Compound 3, a percentage reported as inhibition, at one concentration (the size of the read-out at that concentration, not a potency): 19%
For compound 3 the middle estimate is 14 percentage points below the measured one; the range from low to high includes it.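

Going by these compounds alone, compound 2 has no number in this assay, so no step to compound 3 (19%) can be read. The compounds shown leave open how much methyl in place of hydroxy changes inhibition. No measurement shown here offers an explanation for the result of compound 3.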